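A few compounds are considered here, and "the series" means these few. Any claim that something is new, unique, unknown or untested is made for them only; others in the source may bear on it.

In a functional assay on MCF7 cells (Homo sapiens) for inhibition, read by fluorescence, with a stated time of 72 h (on this read-out lower numbers stand for stronger inhibition and higher numbers for weaker inhibition), compound 1 `CC(C)n1cnc2c(NC(=N)N)nc(N)nc21` gives 97200 nM, compound 2 `CC(C)n1cnc2c(NC(=N)N)nc(NCCCCCCO)nc21` gives 5200 nM and compound 3 `CC[C@H](CO)Nc1nc(NC(=N)N)c2ncn(C(C)C)c2n1` gives 4500 nM. Placing a chain on a nitrogen on an aromatic ring gave a 19-fold lower number from compound 1 to compound 2 (1.27 log units; beyond the scatter) and a 22-fold lower number from compound 1 to compound 3 (1.33 log units; beyond the scatter), both large. Exchanging one chain for the other gave only a 1.2-fold lower number from compound 2 to compound 3 (0.06 log units; within the scatter), within the scatter, so compound 3 stands level with compound 2 and far under compound 1. Compound 4 `CC[C@H](N)COc1nc(NC(=N)N)c2ncn(C(C)C)c2n1` has the same atoms as compound 3, joined differently: 2-aminobutoxy in place of (1-(hydroxymethyl)propyl)amino on an aromatic carbon. Within the data shown here, no measured step swaps a nitrogen link for an oxygen link, so these steps bear on it only loosely, and no change beyond the scatter is expected in this assay. The expected size is a 1.3-fold higher number from compound 3 to compound 4 (0.12 log units; within the scatter). Compound 4 is estimated at 6000 nM, with an expected range of 1500 nM to 24000 nM.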

Compound 4, half-maximal inhibitory concentration: 16300 nM
Compound 4: the middle estimate sits 2.7-fold (0.43 log units) below what was measured; measured number inside the range.
By their numbers in this assay, from the lowest: compounds 3 and 2 (each within the scatter of the next); then compound 4; then compound 1.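

Joining the same atoms differently at this aromatic carbon changes the result in this assay: 2-aminobutoxy gives a 3.6-fold higher number from compound 3 to compound 4 (0.56 log units; beyond the scatter) and a 3.1-fold higher number from compound 2 to compound 4 (0.50 log units; beyond the scatter) so this position responds to how the chain is linked, not only to its atoms. The chain still keeps part of its gain over plain amino, with a 6.0-fold lower number from compound 1 to compound 4 (0.78 log units; beyond the scatter) as the step. Nothing measured here accounts for the difference. Going by these compounds, the oxygen link and the shifted amine change together in compound 4, so which of them matters stays open. An oxygen link carrying a chain that ends in a hydroxyl group would separate the two.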